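Working notes: cyclobutyl in place of cyclopropyl on compound 1

This account rests on a few compounds, and the source may have more. Where it says the series, first, only, none or still open, it means among the compounds named here.

In a physicochemical assay for acid dissociation, compound 1 `O=C1CN(Cc2ccc(-c3ccc(F)c(CN4CCCCC4)n3)cc2)C(=O)N1CC1CC1` gives 8.5 and compound 2 `CN1C(=O)CN(Cc2ccc(-c3cccc(CN4CCCCC4)n3)cc2)C1=O` gives 8.7 on the same scale. Among the compounds with values here, these two values lie within the usual scatter of each other, so compound 1 stands level with the only other measured compound.

Compound 3 `O=C1CN(Cc2ccc(-c3ccc(F)c(CN4CCCCC4)n3)cc2)C(=O)N1CC1CCC1` has cyclobutyl in place of cyclopropyl on a saturated chain carbon bound to an amide-type nitrogen in a ring and otherwise keeps the structure of compound 1.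

Within the data shown here, no measured pair shows a change at this place, so the data offer no direct guide. In this assay no step beyond the scatter is expected, and the estimated no change at the digits printed from compound 1 to compound 3 (within the scatter) serves as the working figure. This expectation starts from compound 1 at 8.5 as measured. In this assay compound 3 is expected at 8.5 with an estimated range of 8.2 to 8.8 as the likely span.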

Compound 3, acid dissociation constant: 8.6
Compound 3: middle estimate off by 0.10 log units, on the low side; the measured number falls inside the stated range.
By their numbers in this assay, from the lowest: compounds 1, 3 and 2 (each within the scatter of the next).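

In this assay, within the data shown here, cyclobutyl in place of cyclopropyl on a saturated chain carbon bound to an amide-type nitrogen in a ring gives a number 0.10 log units higher from compound 1 to compound 3 (within the scatter), which is the first reading of any change at this position. This read-out therefore does not separate cyclopropylmethyl from cyclobutylmethyl at this place, and compound 3 stands level with compound 1. No measured evidence bears on the reason for this result.

Going by these compounds, a single step at this position sets no trend, so the reading for a carboxylic acid, a primary amine or a longer chain such as n-hexyl at this place remains open. Also open, on these data alone, is whether cyclobutyl in place of cyclopropyl would give a similar step on a different core.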